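The compounds below may be only part of what the source reports. "The series", "measured", "known", "first", "only" and "open" are said of these compounds alone.

Within the data shown here, in an ADME assay on RAW264.7 cells (Mus musculus) for cytotoxicity, read by MTT assay, with a stated time of 24 h (a higher number here means that more compound is tolerated, a lower number that less compound is tolerated), compound 1 `CC/C=C\C[C@H]1C(=O)C=C[C@H]1CC(=O)OCCCCC` gives 37 uM as the lowest of the three numbers so far. Compound 2 `CC/C=C\C[C@H]1C(=O)C=C[C@H]1CC(=O)OCCO` gives 161 uM and compound 3 `CC/C=C\C[C@H]1C(=O)C=C[C@H]1CC(=O)OCCOCCOCCOC` gives 163 uM and these two do not separate (a 1.0-fold higher number from compound 2 to compound 3 (0.01 log units; within the scatter)). Compound 4 `CC/C=C\C[C@H]1C(=O)C=C[C@H]1CC(=O)OC(C)C` differs from compound 1 by isopropyl in place of pentyl on an oxygen next to a carbonyl group as isopropyl in place of pentyl on an oxygen next to a carbonyl group. The measured steps on this chain (a 4.4-fold higher number from compound 1 to compound 2 (0.64 log units; beyond the scatter) and a 4.4-fold higher number from compound 1 to compound 3 (0.64 log units; beyond the scatter)) both go upward beyond the scatter, but neither leaves a plain carbon chain in place, so they bear only loosely. A smaller upward step in this assay is therefore expected, possibly not beyond the scatter, and the estimated step is a 1.8-fold higher number from compound 1 to compound 4 (0.24 log units; within the scatter) on that basis. Compound 4 is expected at 65 uM (estimated range 32 uM to 130 uM).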

Compound 4, half-maximal toxic concentration: 58 uM
The estimate for compound 4 lay 1.1-fold (0.05 log units) above the measured number; low and high end bracket the measured number.
By their numbers in this assay, from the lowest: compounds 1 and 4 (each within the scatter of the next); then compounds 2 and 3 (each within the scatter of the next).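

In this assay, isopropyl and pentyl on an oxygen next to a carbonyl group do not separate: a 1.6-fold higher number from compound 1 to compound 4 (0.20 log units; within the scatter). Shortening this plain carbon chain therefore gives no readable gain at this position. Isopropyl in place of 2-hydroxyethyl at the same place gives a 2.8-fold lower number from compound 2 to compound 4 (0.44 log units; beyond the scatter), so compound 4 stands with compound 1 and apart from compound 2.

No evidence is available to explain this result. From the compounds shown here alone, it remains open whether a longer chain, an amine or a carboxylic acid at this place would stand with compound 1 or with compound 2.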